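A few compounds are considered here, and "the series" means these few. Any claim that something is new, unique, unknown or untested is made for them only; others in the source may bear on it.

Measured compounds:
compound 1 `C=C(C)CCOC(=O)C1=C(C)NC(C)=C(C(=O)OC)C1c1cccc([N+](=O)[O-])c1`, 23 nM
compound 2 `CCOC(=O)C1=C(C)NC(C)=C(C(=O)OCC)C1c1cccc(F)c1F`, 15 nM
compound 3 `CCOC(=O)C1=C(C)NC(C)=C(C(=O)OCC)C1c1ccc(F)cc1F`, 20 nM

In a functional assay on HEK293 cells for antagonist activity at Voltage-dependent L-type calcium channel subunit alpha-1C (Oryctolagus cuniculus), read by FLIPR (on this read-out lower numbers stand for stronger inhibition and higher numbers for weaker inhibition), compound 3 stands second highest of the three numbers, with compound 1 nearest and compound 2 furthest, both within the scatter. Compound 4 `CCOC(=O)C1=C(C)NC(C)=C(C(=O)OCC)C1c1ccccc1SC` is not yet measured. The change from compound 3 is 2-(methylsulfanyl)phenyl in place of 2,4-difluorophenyl on a saturated ring carbon. Going by the values given here, the only measured step at the same place, a 1.3-fold higher number from compound 2 to compound 3 (0.12 log units; within the scatter), exchanged one difluorophenyl for another and stayed within the scatter. Among the compounds with values here, no measured step introduces a methylsulfanyl group, so the data give no direction for this change. A step of a 1.1-fold higher number from compound 3 to compound 4 (0.04 log units; within the scatter) is therefore expected, not beyond the scatter. For compound 4 in this assay the estimate is 22 nM, with a range from 7 nM to 70 nM.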

Compound 4, half-maximal inhibitory concentration: 8 nM
For compound 4 the middle estimate is 2.8-fold (0.44 log units) above the measured one; measured number inside the range.
By their numbers in this assay, from the lowest: compounds 4, 2, 3 and 1 (each within the scatter of the next, the first and the last beyond it).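

In this assay, the aryl group on the saturated ring carbon can move the number beyond the scatter: 2-(methylsulfanyl)phenyl in place of 2,4-difluorophenyl gives a clear step (a 2.5-fold lower number from compound 3 to compound 4 (0.40 log units; beyond the scatter)). The same group in place of 2,3-difluorophenyl gives a step that stays within the scatter (a 1.9-fold lower number from compound 2 to compound 4 (0.27 log units; within the scatter)), so the change is readable against only one of the two difluorophenyl compounds. Nothing available explains the step.

Open, as far as these compounds go, is whether the sulfur matters, or whether a methoxy or ethylsulfanyl group on the phenyl ring would read the same.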